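Nitro substitution in a small azo series: cytotoxicity notes

The compounds below may be only part of what the source reports. "The series", "measured", "known", "first", "only" and "open" are said of these compounds alone.

Measured so far:
compound 1 `CN(/N=N/c1ccccc1)c1ccccc1` in an ADME assay on Vero cells (Chlorocebus sabaeus) for cytotoxicity, read by crystal violet staining (on this read-out higher numbers stand for lower toxicity in this test and lower numbers for higher toxicity in this test), gives 50000 nM
compound 2 `CN(C)CCCNc1ccc(/N=N/c2ccccc2)cc1` gives 30000 nM
compound 3 `CN(/N=N/c1cccc([N+](=O)[O-])c1)c1ccccc1` gives > 100000 nM

The value for compound 3 is a limit of the assay and not a number (the limit of > 100000 nM in this assay, at which 1 of the 3 values shown sits). Compound 3 differs from compound 1 by nitro in place of hydrogen on an aromatic carbon, and the step is an at least 2.0-fold higher number from compound 1 to compound 3 (0.30 log units; that floor lies within the scatter), a floor that lies within the scatter. Compound 2 and compound 1 are within the scatter of each other, so no order between them is claimed; how their two cores differ is not broken down here.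

Compound 4 `CN(C)CCCNc1ccc(/N=N/c2ccc([N+](=O)[O-])cc2)cc1` is not yet measured. It differs from compound 2 by nitro in place of hydrogen on an aromatic carbon. The place is not the same word for word as before: for compound 3 the nitro sits meta to a large group, for compound 4 para to a large group, so this is the same kind of change rather than the same change.

From compound 2 to compound 4 in this assay a step of about a 2.0-fold higher number from compound 2 to compound 4 (0.30 log units; within the scatter) is expected, resting on compound 1 to compound 3 giving an at least 2.0-fold higher number from compound 1 to compound 3 (0.30 log units; that floor lies within the scatter). For compound 4 the expected value is therefore around 60000 nM, with a fair chance that only a limit is reported.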

Compound 4, half-maximal cytotoxic concentration: 60000 nM
Compound 4: the middle estimate sits on the measured number at the digits printed; low and high end bracket the measured number.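

In this assay, nitro in place of hydrogen on an aromatic carbon gives a 2.0-fold higher number from compound 2 to compound 4 (0.30 log units; within the scatter), so on this core the change does not separate the two compounds beyond the usual variation between repeats. Set beside the earlier step, the same kind of change reads as follows: the same change on two cores in this assay, an at least 2.0-fold higher number (0.30 log units; that floor lies within the scatter) from compound 1 to compound 3 and a 2.0-fold higher number (0.30 log units; within the scatter) from compound 2 to compound 4; the limit leaves it open whether they differ. Going by these compounds, compound 3 stands at a limit and not a number, so the size of the step on its core stays unknown, and the data show neither a step of equal size on the two cores nor a real gain on either; the nitro also does not occupy the same place in the two pairs: the limit of > 100000 nM in this assay, at which 1 of the 4 values shown sits.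

The compounds shown leave open whether a nitrile or a carboxylic acid in the place of the nitro, para to a large group, would read the same in this assay. Also open, on these data alone, is whether a longer chain on the core of compound 2 would change the picture.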